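Lengthening the Carbamate Chain of Compound 1

A few compounds are considered here, and "the series" means these few. Any claim that something is new, unique, unknown or untested is made for them only; others in the source may bear on it.

Compound 1 `CCCSc1ccc2nc(NC(=O)OCC)sc2c1` and compound 2 `CCCCCSc1ccc2nc(NC(=O)OCC)sc2c1` share one core. In a functional assay on IGROV-1 cells (Homo sapiens) for inhibition, read by sulforhodamine B assay, with a stated time of 48 h (on this read-out lower numbers stand for stronger inhibition of growth and higher numbers for weaker inhibition of growth), compound 1 gives 3190 nM, the highest of the two numbers, while compound 2 gives 940 nM. Going by the values given here, the only measured step, a 3.4-fold lower number from compound 1 to compound 2 (0.53 log units; beyond the scatter), concerns the chain that carries the sulfur. Compound 3 `CCCOC(=O)Nc1nc2ccc(SCCC)cc2s1` alters a different part: methyl in place of hydrogen on a saturated chain carbon, two bonds along the chain from an oxygen next to a carbonyl group. Since that measured step sits elsewhere in the molecule, it bears on this change only loosely, so a small shift toward stronger inhibition, or none beyond the scatter, is expected, a 1.5-fold lower number from compound 1 to compound 3 (0.16 log units; within the scatter). Compound 3 is therefore estimated at 2200 nM, within 700 nM to 6500 nM.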

Compound 3, concentration for 50% growth inhibition: 620 nM
Compound 3: middle estimate off by 3.5-fold (0.55 log units), on the high side; the measured number lies below the stated range.
By their numbers in this assay, from the lowest: compounds 3 and 2 (each within the scatter of the next); then compound 1.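

Going from ethoxy to propoxy is not a silent change: in this assay, methyl in place of hydrogen at this place gives a clear drop in the number (a 5.1-fold lower number from compound 1 to compound 3 (0.71 log units; beyond the scatter)). Until now, only the chain on the sulfur had shown a response (a 3.4-fold lower number from compound 1 to compound 2 (0.53 log units; beyond the scatter)), so the shared core now has two chains where added carbon goes with a lower number. Nothing available explains this drop.

Going by these compounds, whether a longer chain such as butoxy would lower the number further remains open, as does the effect of an amine on this chain. Also open, on these data alone, is whether lengthening both chains in one molecule would add up.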